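From Trifluoromethyl to 1-Hydroxyethyl: an Expected Modest Rise

The compounds below may be only part of what the source reports. "The series", "measured", "known", "first", "only" and "open" are said of these compounds alone.

Of the compounds shown here, three sharing one core have been measured in an assay for binding affinity to Corticotropin releasing factor receptor (Rattus norvegicus); on this read-out lower numbers stand for stronger inhibition and higher numbers for weaker inhibition. Compound 1 `CCCC(C)n1c(CC)nc2c(-c3ccc(/C(C)=N\OC)cc3Cl)ccnc21` gives 2.3 nM. Compound 2 `CCCC(C)n1c(CC)nc2c(-c3ccc(C(C)OC)cc3Cl)ccnc21` gives 3.5 nM. Compound 3 `CCCC(C)n1c(CC)nc2c(-c3ccc(C(F)(F)F)cc3Cl)ccnc21` gives 1.1 nM, the lowest of the three numbers: the step was a 2.1-fold lower number from compound 1 to compound 3 (0.32 log units; beyond the scatter) and a 3.2-fold lower number from compound 2 to compound 3 (0.50 log units; beyond the scatter), while a 1.5-fold higher number from compound 1 to compound 2 (0.18 log units; within the scatter) stayed within the scatter.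

Compound 4 `CCCC(C)n1c(CC)nc2c(-c3ccc(C(C)O)cc3Cl)ccnc21` has not yet been measured. It differs from compound 3 by 1-hydroxyethyl in place of trifluoromethyl on an aromatic carbon. The entering group resembles the 1-methoxyethyl of compound 2 and the methoxy-bearing chain of compound 1, and both of those compounds gave higher numbers than compound 3, as shown by a 3.2-fold lower number from compound 2 to compound 3 (0.50 log units; beyond the scatter) and a 2.1-fold lower number from compound 1 to compound 3 (0.32 log units; beyond the scatter). Running that direction backwards, a modest rise in the number is the likely outcome in this assay, landing near the region of compound 1 and compound 2. Compound 4 is therefore expected to give 4 nM, within a range from 1.5 nM to 12 nM. This corresponds to an expected step of a 3.6-fold higher number from compound 3 to compound 4 (0.56 log units; beyond the scatter).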

Compound 4, inhibition constant: 5.1 nM
For compound 4 the middle estimate is 1.3-fold (0.11 log units) below the measured one, and the stated range covers the measured number.
By their numbers in this assay, from the lowest: compound 3; then compounds 1, 2 and 4 (each within the scatter of the next, the first and the last beyond it).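

In this assay, putting 1-hydroxyethyl, with its hydrogen-bond donor, on this aromatic carbon in place of trifluoromethyl gives a 4.6-fold higher number from compound 3 to compound 4 (0.67 log units; beyond the scatter), a modest loss that shows a hydroxyl-bearing group is tolerated here, though trifluoromethyl keeps the lowest number of the set. Hydrogen in place of methyl on the oxygen gives a 1.5-fold higher number from compound 2 to compound 4 (0.16 log units; within the scatter), so in this small comparison, the free hydroxyl and the methyl ether cannot be told apart. The change from the longer chain of compound 1 is larger, with a 2.2-fold higher number from compound 1 to compound 4 (0.35 log units; beyond the scatter), which places compound 4 clearly apart from compound 1 as well as from compound 3.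

As far as these compounds go, whether an amine, a carboxylic acid or a longer chain ending in a hydroxyl would be accepted on this carbon remains open. Nothing at hand explains why any of these groups gives the number it does.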